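This account rests on a few compounds, and the source may have more. Where it says the series, first, only, none or still open, it means among the compounds named here.

Working notes on the series. Compound 1 `Cc1ccc2cc(CN(Cc3ccc(F)cc3)Cc3ccc(C(C)C)cc3)c(=O)[nH]c2c1` is the starting point; compound 2 `Cc1ccc2cc(CN(Cc3ccc(F)cc3)Cc3ccc(C(C)(C)C)cc3)c(=O)[nH]c2c1` carries methyl in place of hydrogen on a saturated chain carbon bound to an aromatic carbon and two saturated chain carbons, and compound 3 `CCc1ccc2[nH]c(=O)c(CN(Cc3ccc(F)cc3)Cc3ccc(C(C)(C)C)cc3)cc2c1` sits on a different core, where the difference between the two cores is not broken down here.

In a toxicity assay on MDCK cells (Canis lupus familiaris) for cytotoxicity, read by crystal violet staining, with a stated time of 48 h (a lower number here means that less compound is tolerated, a higher number that more compound is tolerated), compound 1 gives only a limit of the assay, > 33000 nM. Compound 2 likewise gives only a limit in this assay, > 33000 nM. For compound 3 this assay again gives only a limit, > 33000 nM. The step that the two limits leave unreadable from compound 1 to compound 2 therefore cannot be sized, because of the limit of > 33000 nM in this assay, at which 3 of the 3 values shown sit.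

Compound 4 `CCCc1ccc2[nH]c(=O)c(CN(Cc3ccc(F)cc3)Cc3ccc(C(C)(C)C)cc3)cc2c1` is not yet measured in this assay. It differs from compound 3 by methyl in place of hydrogen on a saturated chain carbon, two bonds along the chain from an aromatic carbon. This is the same kind of change as that from compound 1 to compound 2, though the place differs: there the carbon is bound to an aromatic carbon and two saturated chain carbons, here it lies two bonds along the chain from an aromatic carbon. With all three values resting at the limit, as the limit of > 33000 nM in this assay, at which 3 of the 3 values shown sit, shows, the step is expected to be a step that the limit leaves unreadable from compound 3 to compound 4. Compound 4 is estimated at 50000 nM, between 20000 nM and 150000 nM, most likely reported only as a limit again.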

Compound 4, half-maximal cytotoxic concentration: 8400 nM
Estimate against measurement, compound 4: 6.0-fold (0.77 log units) above; measured number below the stated range.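

In this assay, among the compounds shown here, the change of ethyl to propyl, methyl in place of hydrogen on a saturated chain carbon two bonds along the chain from an aromatic carbon, gives an at least 3.9-fold lower number from compound 3 to compound 4 (0.59 log units; beyond the scatter) and is the only readable step so far. The same kind of change on the core of compound 1 sits at a different place, and that step cannot be read, so the data do not show whether the effect carries from one core to the other. The size of the new step is also only a bound, since compound 3 gives a limit and not a number: the limit of > 33000 nM in this assay, at which 3 of the 4 values shown sit.

From the compounds shown here alone, it remains open whether a longer chain such as butyl in place of the propyl of compound 4 lowers the number further, or whether a propyl on the core of compound 1 gives a readable value. Also open, going by these compounds, is how an amine or a carboxylic acid at the end of that chain would read.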